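The compounds below may be only part of what the source reports. "The series", "measured", "known", "first", "only" and "open" are said of these compounds alone.

Three compounds share one core and differ only in the ring attached to the aromatic nitrogen. Compound 1 `C=CCc1ccc(OCc2cn(-c3ccc(C#N)cc3)nn2)c(O)c1` carries a 4-cyanophenyl there; in a functional assay on MCF7 cells (Homo sapiens) for inhibition, read by MTT assay, with a stated time of 72 h, tested at 50 uM (a lower number here means less inhibition of growth, a higher number more inhibition of growth at the concentration tested), compound 1 gives 35.6%. Compound 2 `C=CCc1ccc(OCc2cn(-c3ccc(OC)cc3)nn2)c(O)c1` carries a 4-methoxyphenyl instead, and in this assay compound 2 gives 57.2%. Compound 3 `C=CCc1ccc(OCc2cn(-c3cccc(C#N)c3)nn2)c(O)c1` carries a 3-cyanophenyl, and in this assay compound 3 gives 33.4%. Compound 2 holds the highest of the three numbers: the change a number 21.6 percentage points higher from compound 1 to compound 2 (beyond the scatter) lies beyond the scatter, as does a number 23.8 percentage points lower from compound 2 to compound 3 (beyond the scatter), while a number 2.2 percentage points lower from compound 1 to compound 3 (within the scatter) does not.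

Compound 4 `C=CCc1ccc(OCc2cn(-c3ccc(C(=O)c4ccccc4)cc3)nn2)c(O)c1` is not yet measured. It differs from compound 2 in one place: benzoyl in place of methoxy on an aromatic carbon, on an aromatic carbon of a six-membered aromatic ring of carbon only, para to a large group. The measured steps that touch this kind of exchange are a number 21.6 percentage points higher from compound 1 to compound 2 (beyond the scatter) and a number 23.8 percentage points lower from compound 2 to compound 3 (beyond the scatter), both modest. Among the measured compounds shown here, neither involves a benzoyl, so they show only that swapping the group on this ring can move this assay by a modest amount in either direction. For the measured compounds named here, a modest step downward is therefore expected, a number 12.2 percentage points lower from compound 2 to compound 4 (beyond the scatter), with no measured step to anchor it firmly. For compound 4 the estimate in this assay is 45%, with a range from 25% to 65%.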

Compound 4, percent growth inhibition at one concentration: 35.6%
For compound 4 the middle estimate is 9.4 percentage points above the measured one; low and high end bracket the measured number.
By their numbers in this assay, from the lowest: compounds 3, 1 and 4 (each within the scatter of the next); then compound 2.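

Benzoyl is far larger than methoxy, with eight heavy atoms and a ring of its own against two heavy atoms and no ring, and in this assay this exchange gives a number 21.6 percentage points lower from compound 2 to compound 4 (beyond the scatter) and so removes the advantage of compound 2. Benzoyl in place of cyano gives no change at the digits printed from compound 1 to compound 4 (within the scatter) even though the two groups look quite different, so among the three groups tested at this place, only methoxy stands apart, while cyano and benzoyl cannot be told apart. Nothing available here explains what separates methoxy from the other two groups.

On these data alone, whether the higher number belongs to methoxy alone stays open, since an ethoxy, a hydroxyl or an amine at this place could show whether groups close to methoxy keep it. It is also unclear whether an acetyl group would read like benzoyl, which would help show whether the carbonyl or the added ring goes with the lower number.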